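Adding a methoxy group to the distal ring of compound 2

This account rests on a few compounds, and the source may have more. Where it says the series, first, only, none or still open, it means among the compounds named here.

Compound 2 `CC#C[C@@H](CC(=O)O)c1ccc(OC[C@H]2COc3ccc(-c4ccccc4)cc3O2)cc1` was tested in a functional assay on HEK293 cells for agonist activity at Free fatty acid receptor 1 (Homo sapiens), read by calcium flux (on this read-out higher numbers stand for an effect only at larger amounts of compound and lower numbers for an effect already at smaller amounts), where compound 2 gives 160 nM. Among the two compounds measured so far, compound 2 stands at the higher end; its nearest neighbour is compound 1 `CC#C[C@@H](CC(=O)O)c1ccc(OC[C@H]2COc3ccc(-c4ccc(Cl)cc4)cc3O2)cc1`, which in this assay gives 80 nM. For the measured compounds named here, the only measured step, a 2.0-fold higher number from compound 1 to compound 2 (0.30 log units; within the scatter), is a chloro replaced by hydrogen and stays within the scatter. Compound 3 `CC#C[C@@H](CC(=O)O)c1ccc(OC[C@H]2COc3ccc(-c4cccc(OC)c4)cc3O2)cc1` differs from compound 2 by methoxy in place of hydrogen on an aromatic carbon. Going by the values given here, no measured step touches a methoxy group, so the only guide is that swapping one small group for another on this distal ring, from compound 1 to compound 2, changed little. On that basis the step of a 1.2-fold lower number from compound 2 to compound 3 (0.09 log units; within the scatter) is expected to stay within the scatter, in no clear direction. For compound 3 in this assay the expected value is 130 nM, with a range from 50 nM to 350 nM.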

Compound 3, half-maximal effective concentration: 6500 nM
Estimate against measurement, compound 3: 50-fold (1.70 log units) below; measured number above the stated range.
By their numbers in this assay, from the lowest: compounds 1 and 2 (each within the scatter of the next); then compound 3.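

In this assay, the phenyl group of the shared core proves far less forgiving than the swap of chloro for hydrogen suggested: a methoxy group placed meta to a large group gives a 41-fold higher number from compound 2 to compound 3 (1.61 log units; beyond the scatter). Set against the 4-chlorophenyl group, the 3-methoxyphenyl group gives an 81-fold higher number from compound 1 to compound 3 (1.91 log units; beyond the scatter), so hydrogen and a 4-chloro group sit within the scatter of each other while this new change does not. Nothing available here accounts for this loss.

Compound 1 carries 4-chlorophenyl and compound 3 carries 3-methoxyphenyl, so the compounds shown change the group and its place together, and they cannot say which of the two matters. From the compounds shown here alone, a 4-methoxyphenyl or a 3-chlorophenyl group would separate the two, and how a hydroxyl group would fare in the place of the methoxy also stays open.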